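The source may hold more compounds than are shown below. What is called first, only, known or untested is meant among the compounds shown, and "the series" means these compounds.

Compound 2 `CC(C)n1cc(-c2cc(C(O)(C(F)(F)F)C(F)(F)F)cnc2N2CCN(S(=O)(=O)c3ccc(N)nc3)CC2)cn1` gives 198 mL.min-1.g-1 in an ADME assay (liver) for metabolic stability, with Liver microsome (Rattus norvegicus) as the target, using microsomes and NADPH, with a stated time of 30 min, tested at 1 uM (on this read-out lower numbers stand for slow clearance and higher numbers for fast clearance), and among the three compounds measured it stands highest, so this set places it at the fast end of the read-out. Its two neighbours sit lower: compound 1 `Nc1ccc(S(=O)(=O)N2CCN(c3ncc(C(O)(C(F)(F)F)C(F)(F)F)cc3C#CCCO)CC2)cn1` gives 68 mL.min-1.g-1 and compound 3 `NC(=O)c1cccc(-c2cc(C(O)(C(F)(F)F)C(F)(F)F)cnc2N2CCN(S(=O)(=O)c3ccc(N)nc3)CC2)c1` gives 63 mL.min-1.g-1 in this assay.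

Compound 4 `Nc1ccc(S(=O)(=O)N2CCN(c3ncc(C(O)(C(F)(F)F)C(F)(F)F)cc3-c3cccnc3)CC2)cn1` differs from compound 2 in one place. pyridin-3-yl in place of 1-isopropyl-1H-pyrazol-4-yl on an aromatic carbon

The measured steps that bear on this change both involve the 1-isopropyl-1H-pyrazol-4-yl group on the same aromatic carbon. In this assay the step of a 2.9-fold higher number from compound 1 to compound 2 (0.46 log units; beyond the scatter) and the step of a 3.1-fold lower number from compound 2 to compound 3 (0.50 log units; beyond the scatter) each show that the compound carrying that group sits on the fast side, while replacing it with a 3-carbamoylphenyl group or a 4-hydroxybut-1-yn-1-yl group brings the number back down by a modest amount. Nothing is known here about a pyridin-3-yl group in this position, but as it is another six-membered aromatic ring entering at the same place, compound 4 is expected to move in the same direction as compound 3, with a step of about a 2.5-fold lower number from compound 2 to compound 4 (0.39 log units; beyond the scatter) in this assay. Compound 4 is therefore estimated at 80 mL.min-1.g-1, with a range from 40 mL.min-1.g-1 to 160 mL.min-1.g-1.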

Compound 4, intrinsic clearance in microsomes: 20 mL.min-1.g-1
Compound 4: middle estimate off by 4.0-fold (0.60 log units), on the high side, outside the stated range (below it).
By their numbers in this assay, from the lowest: compound 4; then compounds 3 and 1 (each within the scatter of the next); then compound 2.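

In this assay the pyridin-3-yl group sets a new low end for this aromatic carbon, with a 3.2-fold lower number from compound 3 to compound 4 (0.50 log units; beyond the scatter) and a 3.4-fold lower number from compound 1 to compound 4 (0.53 log units; beyond the scatter), so neither of the two lower earlier compounds marks the floor of the series. Compounds 3 and 4 both carry a six-membered aromatic ring here and still lie apart beyond the scatter, which shows that ring size alone does not fix the number, while a 9.9-fold lower number from compound 2 to compound 4 (1.00 log units; beyond the scatter) is the widest step yet seen at this place and shows that the span reachable through this one substituent is larger than the first three compounds suggested. Nothing shown here offers any measured explanation of why the pyridin-3-yl group stands lowest.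

From the compounds shown here alone, whether the nitrogen of the pyridin-3-yl group matters stays open, and a plain phenyl group or a pyridin-4-yl group on the same carbon would be needed to separate the part played by that atom from the part played by the ring itself. Going by these compounds, it is also open whether the low number would hold if the 2,2,2-trifluoro-1-hydroxy-1-(trifluoromethyl)ethyl group gave way to a carboxylic acid or another group elsewhere on the shared core.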